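The source may report more compounds than this note shows. Statements on the series, on what has been measured and on what is new or still open speak of the compounds shown alone.

Working notes on the series.

Compound 1, `CC1=C(C(=O)Nc2ccc(F)cc2)C(c2ccc([N+](=O)[O-])cc2)n2c(s/c(=C/c3ccccc3Cl)c2=O)=N1`, carries a nitro group on one of its aryl rings; in a functional assay on the whole organism (strain albino) for inhibition, with Rattus norvegicus as the target, read by paw edema, with stated times of 1 h and 3 h, at a dose of 25 mg/kg by the oral route (on this read-out higher numbers stand for more inhibition at the one dose given (going by the name of the read-out) and lower numbers for less inhibition), compound 1 gives 19%. Compound 2, `CC1=C(C(=O)Nc2ccc(F)cc2)C(c2ccc(Cl)cc2)n2c(s/c(=C/c3ccccc3Cl)c2=O)=N1`, is obtained from compound 1 by chloro in place of nitro on an aromatic carbon and in this assay compound 2 gives 16%. The step of a number 3 percentage points lower from compound 1 to compound 2 (within the scatter) is the only measured case of this change so far, and it leaves the read-out essentially where it was.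

Compound 3, `CC1=C(C(=O)Nc2ccc(F)cc2)C(c2ccc(F)cc2)n2c(s/c(=C/c3ccc([N+](=O)[O-])cc3)c2=O)=N1`, belongs to the same series but rests on a different core; how its core differs from that of compound 1 is not broken down here. In this assay compound 3 gives 30%, the highest of the three measured numbers, and its distance to compound 1 as well as to compound 2 is beyond the scatter.

Compound 4, `CC1=C(C(=O)Nc2ccc(F)cc2)C(c2ccc(F)cc2)n2c(s/c(=C/c3ccc(Cl)cc3)c2=O)=N1`, is not yet measured. It stands to compound 3 as compound 2 stands to compound 1: the difference is chloro in place of nitro on an aromatic carbon, at the same kind of position on the same kind of ring, so the change is the same one that was already measured once. Because the step of a number 3 percentage points lower from compound 1 to compound 2 (within the scatter) stayed within the scatter, the step from compound 3 to compound 4 is also expected to be small, a number 3 percentage points lower from compound 3 to compound 4 (within the scatter), with the read-out of compound 4 expected to remain near that of compound 3 rather than falling back toward compound 1 or compound 2. Compound 4 is therefore estimated at 27%, with an expected range from 17% to 37%.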

Compound 4, a percentage reported as inhibition, in the whole organism at one dose (the size of the read-out at that dose, not a potency): 47%
Compound 4: the middle estimate sits 20 percentage points below what was measured; measured number outside the range, above it.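

The change of nitro to chloro does not carry over from one core to the other at a fixed size: in this assay, the core of compound 3 gives a number 17 percentage points higher from compound 3 to compound 4 (beyond the scatter), and this step, unlike the earlier one, lies beyond the scatter. Set side by side, the two measured cases show that the outcome of this change in the series depends on its structural setting: the same change on two cores in this assay, a number 3 percentage points lower (within the scatter) from compound 1 to compound 2 and a number 17 percentage points higher (beyond the scatter) from compound 3 to compound 4, 20 percentage points apart, beyond the scatter of two such steps. This does not show which feature of the cores sets the size of the step, since the two pairs differ from each other in more than one place, and two pairs at a single dose give neither a rule for further cores nor a reason for the gap.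

The compounds shown leave open how other groups at this place, such as an amine or a carboxylic acid, would behave on either core, and whether a third core would follow the pair of compound 1 and compound 2 or that of compound 3 and compound 4. As far as these compounds go, the fluoro-bearing aryl group on the amide is also the same throughout, so the effect of replacing it with a longer chain on the size of this step remains open.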